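The source may report more compounds than this note shows. Statements on the series, on what has been measured and on what is new or still open speak of the compounds shown alone.

In an ADME assay on Vero cells (Chlorocebus sabaeus) for cytotoxicity, with a stated time of 5 days (on this read-out lower numbers stand for higher toxicity in this test and higher numbers for lower toxicity in this test), compound 1 `C[C@@]1(O)[C@H](O)[C@@H](CO)O[C@H]1n1cnc2c(N)nc(NN)nc21` gives > 100000 nM, a limit of the assay and not a number. Compound 2 `C[C@@]1(O)[C@H](O)[C@@H](CO)O[C@H]1n1cnc2c(N)nc(N=[N+]=[N-])nc21` gives > 100000 nM, which is also a limit. Compound 2 therefore has no numeric position in the series, and the standing is the limit of > 100000 nM in this assay, at which 2 of the 2 values shown sit.

Compound 3 `C[C@@]1(O)[C@H](O)[C@@H](CO)O[C@H]1n1cnc2c(N)nc(-n3cc([Si](C)(C)C)nn3)nc21` differs from compound 2 by one change on an aromatic carbon: a group of 9 heavy atoms (5 carbon, 3 nitrogen, 1 silicon; one five-membered aromatic ring with 3 hetero atoms) in place of a group of 3 heavy atoms (3 nitrogen; no ring), on an aromatic carbon. Azido leaves, and a group with no common name enters, carrying one five-membered aromatic ring with 3 hetero atoms.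

Going by the values given here, only one measured step bears on this change, and it is a step that the two limits leave unreadable from compound 1 to compound 2. Among the compounds with values here, it gives no size to carry over, and no measured step covers a group of this kind. The expectation starts from compound 2 at > 100000 nM, a limit from which only a move toward lower numbers could be read. Little or no change is expected in this assay, with any shift expected toward lower numbers. The expected step is an at least 1.2-fold lower number from compound 2 to compound 3 (0.09 log units; that floor lies within the scatter). The estimate for compound 3 is 80000 nM. The expected range for compound 3 runs from 25000 nM to 150000 nM.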

Compound 3, half-maximal cytotoxic concentration: > 100000 nM
Compound 3: only a limit was reported; the forecaster's own chance of this, stated with the estimate: 60%; middle value at least 1.2-fold (0.09 log units) away from the limit.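

In this assay compound 3 gives > 100000 nM, a limit of the assay and not a number. Going by these compounds alone, no step among compound 1, compound 2 and compound 3 can be read, so no new size is available. The series stands at one place: the limit of > 100000 nM in this assay, at which 3 of the 3 values shown sit. Still open, as far as these compounds go, is whether any group on this aromatic carbon gives a numeric value on this read-out.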